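Piperidinyl amide replacing the dimethylaminoethyl chain

A few compounds are considered here, and "the series" means these few. Any claim that something is new, unique, unknown or untested is made for them only; others in the source may bear on it.

Compound 1 `Cc1ccc2[nH]c(C(=O)N[C@H]3CN(S(=O)(=O)c4ccccc4)C[C@@H]3C(=O)NCCN(C)C)cc2c1` holds the highest of the three numbers in an ADME assay on cells (Hepatocyte, Rattus norvegicus) for metabolic stability (on this read-out lower numbers stand for slow clearance and higher numbers for fast clearance), giving 16 uL/min. Compound 2 `Cc1ccc2[nH]c(C(=O)N[C@H]3CN(S(=O)(=O)c4cccnc4)C[C@@H]3C(=O)NCCN(C)C)cc2c1` gives 8 uL/min in this assay, a move of a 2.0-fold lower number from compound 1 to compound 2 (0.30 log units; within the scatter). Compound 3 `Cc1ccc2[nH]c(C(=O)N[C@H]3CN(S(=O)(=O)C4CCOCC4)C[C@@H]3C(=O)NCCN(C)C)cc2c1` gives 4 uL/min, a move of a 4.0-fold lower number from compound 1 to compound 3 (0.60 log units; beyond the scatter); between the two it is a 2.0-fold lower number from compound 2 to compound 3 (0.30 log units; within the scatter). All three measured steps alter the group on the sulfonyl sulfur. Compound 4 `Cc1ccc2[nH]c(C(=O)N[C@H]3CN(S(=O)(=O)c4ccccc4)C[C@@H]3C(=O)N[C@H]3CCCNC3)cc2c1` differs from compound 1 elsewhere: piperidin-3-yl in place of 2-(dimethylamino)ethyl on an amide-type nitrogen. Among the compounds with values here, no measured step touches that amide-type nitrogen, so the measured steps give no direct guide, and no step beyond the scatter is expected in this assay. Compound 4 is therefore estimated to give 16 uL/min, within 6 uL/min to 40 uL/min. The expected step is no change at the digits printed from compound 1 to compound 4 (within the scatter), within the scatter.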

Compound 4, intrinsic clearance in a liver preparation (reported as CLH), per the amount of preparation that the assay uses: 7 uL/min
For compound 4 the middle estimate is 2.3-fold (0.36 log units) above the measured one; the measured number falls inside the stated range.
By their numbers in this assay, from the lowest: compounds 3, 4, 2 and 1 (each within the scatter of the next, the first and the last beyond it).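

In this assay, within the data shown here, the amide-type nitrogen, which no earlier step touched, proves able to shift the read-out: piperidin-3-yl in place of 2-(dimethylamino)ethyl gives a 2.3-fold lower number from compound 1 to compound 4 (0.36 log units; beyond the scatter), a modest step beyond the scatter. The group on the sulfonyl sulfur is thus not the only place where this read-out moves. No evidence is available to explain this step.

Going by these compounds, it remains open whether the step carries over to compounds with pyridin-3-yl or oxan-4-yl on the sulfonyl sulfur. Also open, on these data alone, is how piperidin-4-yl, pyrrolidin-3-yl or a longer aminoalkyl chain on this nitrogen would compare.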